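Working notes: fluoro replaces hydrogen on the phenyl

The compounds below may be only part of what the source reports. "The series", "measured", "known", "first", "only" and "open" are said of these compounds alone.

Measured so far:
- compound 1 `COc1cc(OC)c2c(=O)cc(/C=C/c3ccncc3)oc2c1`: in a functional assay on PC-3 cells (Homo sapiens) for antiproliferative activity, read by MTT assay, with a stated time of 12 h (on this read-out higher numbers stand for weaker inhibition and lower numbers for stronger inhibition), compound 1 gives > 40000 nM, a limit of the assay and not a number.
- compound 2 `COc1cc(OC)c2c(=O)cc(/C=C/c3ccccc3)oc2c1`: in this assay compound 2 gives > 40000 nM, likewise a limit.
- compound 3 `COc1cccc2oc(/C=C/c3ccc(OC(F)(F)F)cc3)cc(=O)c12`: in this assay compound 3 gives > 40000 nM, again a limit.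

Compound 2 therefore stands only at a limit in this assay; no number is known for it, and the two other values shown are limits as well. Among the compounds with values here, the single step between measured compounds, a step that the two limits leave unreadable from compound 1 to compound 2, cannot be read because the limit of > 40000 nM in this assay, at which 3 of the 3 values shown sit, holds at both of its ends.

Compound 4 `COc1cc(OC)c2c(=O)cc(/C=C/c3ccc(F)cc3)oc2c1` differs from compound 2 by fluoro in place of hydrogen on an aromatic carbon. Within the data shown here, no measured step involves a fluoro group, and the one step that exists is unreadable, so nothing in the numbers points to a change in either direction. The expectation for compound 4 in this assay is that it remains at the limit, estimated at 40000 nM with a range from 15000 nM to 100000 nM. The expected step is a number no higher from compound 2 to compound 4 (the limit leaves the size open), meaning none beyond the scatter.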

Compound 4, half-maximal inhibitory concentration: > 40000 nM
Compound 4: only a limit was reported; the forecaster's own chance of this, stated with the estimate: 80%; the middle value lies on the limit itself.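

The steps from compound 2 to compound 4 and from compound 1 to compound 4 cannot be read, as both ends of each sit at: the limit of > 40000 nM in this assay, at which 4 of the 4 values shown sit.

The compounds shown leave open whether fluoro in place of hydrogen, or any other change to the series, has any effect that can be read in this assay.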